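The source may report more compounds than this note shows. Statements on the series, on what has been measured and on what is new or still open speak of the compounds shown alone.

Two compounds of the series carry a measured value in an assay on HEK293 cells for inhibition of Nitric oxide synthase, inducible (Homo sapiens), read by fluorescence; on this read-out lower numbers stand for stronger inhibition and higher numbers for weaker inhibition. Compound 1 `O=c1cc(CN(c2cccnc2)c2cccc(Cl)c2)c2ccc(F)c(F)c2[nH]1` gives 77 nM in this assay, and compound 2 `O=c1cc(CN(Cc2ccc(Cl)cc2)c2cnccn2)c2ccc(F)c(F)c2[nH]1` gives 77 nM, so compound 1 stands level with compound 2, within the scatter. Compound 3 `CN(C)c1nccc(N(Cc2cc(=O)[nH]c3c(F)c(F)ccc23)c2cccc(Cl)c2)n1` is not yet measured; it differs from compound 1 in one place: 2-(dimethylamino)pyrimidin-4-yl in place of pyridin-3-yl on a nitrogen on an aromatic ring. Among the measured compounds shown here, no measured pair tests an exchange of this kind, so the data give no anchor for its size. A step of modest size, in either direction and not far beyond the scatter, is expected, a 1.3-fold higher number from compound 1 to compound 3 (0.11 log units; within the scatter). For compound 3 the estimate in this assay is 100 nM, with a range from 25 nM to 400 nM.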

Compound 3, half-maximal inhibitory concentration: 1300 nM
Compound 3: the middle estimate sits 13-fold (1.11 log units) below what was measured, and the stated range ends below it.
By their numbers in this assay, from the lowest: compounds 1 and 2 (each within the scatter of the next); then compound 3.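

The nitrogen on an aromatic ring is not indifferent to what it carries: in this assay, 2-(dimethylamino)pyrimidin-4-yl in place of pyridin-3-yl gives a 17-fold higher number from compound 1 to compound 3 (1.23 log units; beyond the scatter), a large step beyond the scatter. Compounds 1 and 2 alone gave no measure of how much an exchange at this place can cost. No measured evidence bears on the origin of this step.

The compounds shown do not separate the dimethylamino group from the pyrimidine ring as the part carrying the step. An unsubstituted pyrimidin-4-yl on the same nitrogen would bear on that question.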